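From Cyclopropylmethyl to Cyclopentyl on the Ring Nitrogen

The source may report more compounds than this note shows. Statements on the series, on what has been measured and on what is new or still open speak of the compounds shown alone.

Measured so far in a functional assay on RAW264.7 cells (Mus musculus) for inhibition, read by Griess assay, with stated times of 2 h and 24 h; a lower number here means a stronger inhibitor, a higher number a weaker inhibitor:
Compound 1, `CCCCn1cc(COc2cc(O)c3c(c2)O[C@H](c2ccc(OC)c(O)c2)C/C3=N\O)nn1`, gives 8900 nM.
Compound 2, `COc1ccc([C@@H]2C/C(=N\O)c3c(O)cc(OCc4cn(CC5CC5)nn4)cc3O2)cc1O`, gives 6320 nM.
Compound 3, `COc1ccc([C@@H]2CC(=O)c3c(O)cc(OCc4cn(Cc5cccc(C(F)(F)F)c5)nn4)cc3O2)cc1O`, gives 19900 nM.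

Compound 2 has the lowest number of the three, with compound 1 inside the usual scatter of it and compound 3 above it beyond the scatter. Compound 4, `COc1ccc([C@@H]2C/C(=N\O)c3c(O)cc(OCc4cn(C5CCCC5)nn4)cc3O2)cc1O`, differs from compound 2 in one place: cyclopentyl in place of cyclopropylmethyl on an aromatic nitrogen. Within the data shown here, only one measured step concerns the group on this aromatic nitrogen, a 1.4-fold lower number from compound 1 to compound 2 (0.15 log units; within the scatter), and it stayed within the scatter. Compound 3 carries a different group there and also differs elsewhere in the shared core, so it offers no clean comparison. Another exchange among small saturated carbon groups is therefore expected to change this assay little; the expected outcome is a 1.1-fold lower number from compound 2 to compound 4 (0.02 log units; within the scatter). Compound 4 is estimated at 6000 nM, within 2500 nM to 15000 nM.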

Compound 4, half-maximal inhibitory concentration: 6880 nM
Estimate against measurement, compound 4: 1.1-fold (0.06 log units) below, and the stated range covers the measured number.
By their numbers in this assay, from the lowest: compounds 2, 4 and 1 (each within the scatter of the next); then compound 3.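

In this assay the group on this aromatic nitrogen can now be a five-membered ring bound directly to it: cyclopentyl gives a 1.1-fold higher number from compound 2 to compound 4 (0.04 log units; within the scatter) against cyclopropylmethyl and a 1.3-fold lower number from compound 1 to compound 4 (0.11 log units; within the scatter) against butyl. Butyl, cyclopropylmethyl and cyclopentyl therefore cannot be told apart here, whether the group is an open chain or a ring. No measurement available explains this.

Still open, on these data alone, is whether an amine or a carboxylic acid on this group would move the number beyond the scatter. The same question stands for a much longer chain.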